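The source may report more compounds than this note shows. Statements on the series, on what has been measured and on what is new or still open speak of the compounds shown alone.

Among the compounds with values here, in a functional assay on PC-3 cells (Homo sapiens), read by MTT assay, with a stated time of 48 h (a lower number here means a stronger inhibitor, a higher number a weaker inhibitor), compound 2 `CCOC(=O)CN(C)C(=O)c1ccc(C(CC)(CC)c2ccc(OCC(O)C(C)(C)C)c(C)c2)n1CC` gives 25500 nM, the highest of the three numbers so far. Compound 3 `CCn1c(C(=O)NCCN(C)C)ccc1C(CC)(CC)c1ccc(OCC(O)C(C)(C)C)c(C)c1` gives 1630 nM. Compound 1 `CCn1c(C(=O)NCCN)ccc1C(CC)(CC)c1ccc(OCC(=O)C(C)(C)C)c(C)c1` gives 480 nM, but it differs from compound 2 in more than one place. Compound 4 `C#CCNC(=O)c1ccc(C(CC)(CC)c2ccc(OCC(O)C(C)(C)C)c(C)c2)n1CC` is still unmeasured. It carries propargylamino in place of ((ethoxycarbonyl)methyl)(methyl)amino on a carbonyl carbon. Within the data shown here, the one measured step at this place is large: a 16-fold lower number from compound 2 to compound 3 (1.19 log units; beyond the scatter). That step leaves the same group, but a different one enters, so a lower number is expected again, by a smaller margin. The expected change is a 4.3-fold lower number from compound 2 to compound 4 (0.63 log units; beyond the scatter). Compound 4 is estimated at 6000 nM, with an expected range from 1800 nM to 20000 nM.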

Compound 4, half-maximal inhibitory concentration: 16200 nM
Compound 4: the middle estimate sits 2.7-fold (0.43 log units) below what was measured; measured number inside the range.
By their numbers in this assay, from the lowest: compound 1; then compound 3; then compounds 4 and 2 (each within the scatter of the next).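

In this assay, replacing ((ethoxycarbonyl)methyl)(methyl)amino on this carbonyl carbon does not by itself bring the large drop seen with compound 3: the result is a 1.6-fold lower number from compound 2 to compound 4 (0.20 log units; within the scatter). With the amide hydrogen present in both compounds, the chain end matters, and exchanging (dimethylamino)methyl for ethynyl gives a 9.9-fold higher number from compound 3 to compound 4 (1.00 log units; beyond the scatter).

From the compounds shown here alone, whether a longer chain ending in dimethylamino, or a carboxylic acid, at this place would match compound 3 remains open. The data offer no explanation for the gap between compound 3 and compound 4.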